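A few compounds are considered here, and "the series" means these few. Any claim that something is new, unique, unknown or untested is made for them only; others in the source may bear on it.

Of the compounds shown here, three have been tested so far, all built on one shared core that carries a chlorine: compound 1 `O=c1[nH]c(Nc2cc(Cl)cc(Cl)c2)nc2cc(Cl)ccc12`, compound 2 `O=c1[nH]c(NCC2CCCCC2)nc2cc(Cl)ccc12` and compound 3 `CC(C)Nc1nc2cc(Cl)ccc2c(=O)[nH]1`. Each was run in an ADME assay on Vero cells (Chlorocebus sabaeus) for cytotoxicity, read by WST assay; on this read-out higher numbers stand for lower toxicity in this test and lower numbers for higher toxicity in this test. In this assay compound 1 gives only a limit of the assay, > 25000 nM. Compound 2 likewise stops at a limit, > 25000 nM. Compound 3 also reaches no more than a limit, > 25000 nM. Among the compounds with values here, the picture is therefore uniform: the limit of > 25000 nM in this assay, at which 3 of the 3 values shown sit, so no compound can be ranked against another, and compound 3 simply stands where the other two stand, at the edge of what the assay can report.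

Compound 4 `CCCCNc1nc2cc(Cl)ccc2c(=O)[nH]1` is the next candidate. Compared with compound 3 it carries butyl in place of isopropyl on a nitrogen on an aromatic ring. Within the data shown here, no pair of measured compounds differs in just one place, so there is no measured step to lean on; what exists is three results that all sit at the limit. On that basis the change from compound 3 to compound 4 is expected to move nothing beyond the scatter, which is the meaning of the expected step that the limit leaves unreadable from compound 3 to compound 4. For compound 4 itself the estimate in this assay is 50000 nM, with a likely range from 25000 nM to 150000 nM, most probably reported again only as a limit.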

Compound 4, half-maximal cytotoxic concentration: > 25000 nM
Compound 4 ended at the assay's limit; the forecaster's own chance of this, stated with the estimate: 85%; the middle value lies beyond the limit too.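

No step to compound 4 from compound 3 or from compound 2 can be read, because all of these compounds give only a limit in this assay: the limit of > 25000 nM in this assay, at which 4 of the 4 values shown sit. The compounds shown leave open how toxic any of them is to these cells, and whether the group on the nitrogen makes any difference to that.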